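The compounds below may be only part of what the source reports. "The series", "measured", "known", "first", "only" and "open" are said of these compounds alone.

Three compounds built on one shared core have been examined in a functional assay on HepG2 cells (Homo sapiens) for antiproliferative activity, read by MTT assay, with a stated time of 72 h; a higher number here means a weaker inhibitor, a lower number a stronger inhibitor. Compound 1 `O=C1COc2ccc(-c3cnc4ccccc4c3)cc2N1c1ccccc1` carries a plain phenyl on the amide-type nitrogen in a ring; in this assay compound 1 gives only a limit of the assay, > 40000 nM, which is the limit of > 40000 nM in this assay, at which 1 of the 3 values shown sits. Compound 2 `O=C1COc2ccc(-c3cnc4ccccc4c3)cc2N1c1ccc(Cl)cc1` carries a 4-chlorophenyl on that nitrogen, and in this assay compound 2 gives 32700 nM. Compound 3 `COc1cccc(N2C(=O)COc3ccc(-c4cnc5ccccc5c4)cc32)c1` carries a 3-methoxyphenyl on that nitrogen, and in this assay compound 3 gives 2080 nM, the lowest of the two real numbers; its nearest neighbour is compound 2, reached by the step of a 16-fold lower number from compound 2 to compound 3 (1.20 log units; beyond the scatter). From the other side, the step of an at least 19-fold lower number from compound 1 to compound 3 (1.28 log units; beyond the scatter) points the same way.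

Compound 4 `O=C1COc2ccc(-c3cnc4ccccc4c3)cc2N1C1CCCCC1` differs from compound 3 in a single place: cyclohexyl in place of 3-methoxyphenyl on an amide-type nitrogen in a ring. Among the compounds with values here, the steps that bear on this change are a 16-fold lower number from compound 2 to compound 3 (1.20 log units; beyond the scatter) and an at least 19-fold lower number from compound 1 to compound 3 (1.28 log units; beyond the scatter), both large, and both tie the lowest number to the 3-methoxyphenyl. Taking that group away, and with it the only aromatic ring on that nitrogen, is therefore expected to move the number back up toward the weaker compounds 1 and 2. For compound 4 the expected step is a 7.2-fold higher number from compound 3 to compound 4 (0.86 log units; beyond the scatter), toward a higher number. Compound 4 is accordingly estimated at 15000 nM, within a range from 4000 nM to 40000 nM.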

Compound 4, half-maximal inhibitory concentration: > 40000 nM
Compound 4: only a limit was reported (the forecaster's own chance of this, stated with the estimate: 30%); middle value at least 2.6-fold (0.42 log units) away from the limit.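

With cyclohexyl on the amide-type nitrogen in a ring, the result is an at least 19-fold higher number from compound 3 to compound 4 (1.28 log units; beyond the scatter) and the low number of compound 3 is lost, so a six-membered ring of carbon on that nitrogen is not enough by itself. Compounds 1 and 2 carry an aromatic ring there and still give high numbers, so among these four compounds only the 3-methoxyphenyl goes with a low number, and neither an aromatic nor a non-aromatic ring alone does. Set against the 4-chlorophenyl, the change gives an at least 1.2-fold higher number from compound 2 to compound 4 (0.08 log units; that floor lies within the scatter) and this floor does not separate compound 4 from compound 2, while the step between compound 1 and compound 4 cannot be read, as both compounds give only a limit of the assay: the limit of > 40000 nM in this assay, at which 2 of the 4 values shown sit.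

Still open, going by these compounds, is whether the low number of compound 3 rests on the methoxy group itself, which a hydroxy group or an amine in its place on the phenyl ring would test. A longer chain on the same nitrogen, with no ring at all, would show whether that nitrogen needs a ring to carry any activity.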